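Estimating compound 3 from a single measured neighbour

The source may hold more compounds than are shown below. What is called first, only, known or untested is meant among the compounds shown, and "the series" means these compounds.

Among the measured compounds shown here, in an ADME assay on J774.A1 cells (Mus musculus) for cytotoxicity, read by MTT assay, with a stated time of 72 h (on this read-out higher numbers stand for lower toxicity in this test and lower numbers for higher toxicity in this test), compound 1 (`CC1(c2ccc(NC(c3ccc(Br)cc3)c3nnnn3C(C)(C)C)cc2)NC(=O)c2ccccc2N1`) gives 400000 nM, the only number so far. Compound 2 (`CC1(c2ccc(NC(c3cccc4ccccc34)c3nnnn3C(C)(C)C)cc2)NC(=O)c2ccccc2N1`) shares the core of compound 1, but the entry of compound 2 reads "not determined" (no result reported), so compound 2 has no place on the scale and offers no starting value. Compound 3 (`COc1ccc(C(Nc2ccc(C3(C)NC(=O)c4ccccc4N3)cc2)c2nnnn2C(C)(C)C)cc1`) is the next to be read. The structural change is 4-methoxyphenyl in place of naphthalen-1-yl on a saturated chain carbon bound to an aromatic carbon and a nitrogen on an aromatic ring. For the measured compounds named here, no step between measured compounds exists in this assay, so no shift beyond the usual scatter is expected in either direction, and the only reference is compound 1 at 400000 nM. For compound 3 the estimated value is 300000 nM, with an expected range of 100000 nM to 600000 nM.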

Compound 3, half-maximal cytotoxic concentration: > 400000 nM
Compound 3 gave a limit, no number; the forecaster's own chance of this, stated with the estimate: 25%; middle value at least 1.3-fold (0.12 log units) away from the limit.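

In this assay the exchange of bromo for methoxy on an aromatic carbon gives the first readable direction at this position, a number no lower from compound 1 to compound 3 (the limit leaves the size open). On this read-out that direction means no higher toxicity in this test, so the 4-methoxyphenyl group keeps the series at the top of the range shown. Compound 3 gives only a limit, not a number, so the result carries a direction without a size: the limit of > 400000 nM in this assay, at which 1 of the 3 values shown sits.

As far as these compounds go, how far the value of compound 3 lies from that of compound 1 stays open, and the naphthalen-1-yl group of compound 2 still has no place on the scale. Also open, from the compounds shown here alone, is whether an amine, a carboxylic acid or a longer alkoxy chain on the same aromatic carbon would give a readable number in this assay.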